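Sigma-1 binding: cyclohexyl to 4-fluorophenyl on the piperazine

The source may report more compounds than this note shows. Statements on the series, on what has been measured and on what is new or still open speak of the compounds shown alone.

Measured so far:
- compound 1 `O=c1oc(-c2ccccc2)nn1CCCCN1CCN(c2ccc(F)cc2)CC1`: in an assay on cell membranes for displacement of a labelled ligand from Sigma non-opioid intracellular receptor 1 (Cavia porcellus), read by scintillation counting, with a stated time of 120 min (a lower number here means a stronger inhibitor, a higher number a weaker inhibitor), compound 1 gives 383 nM
- compound 2 `COc1cc2c(cc1OC)CN(CCCCn1nc(-c3ccccc3)oc1=O)CC2`: in this assay compound 2 gives 1600 nM
- compound 3 `O=C1CCc2ccccc2N1CCCCN1CCN(C2CCCCC2)CC1`: in this assay compound 3 gives 21 nM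

Compound 3 has the lowest number of the three in this assay; compound 1 sits well beyond the scatter from it, and compound 2 further still. Compound 1 and compound 2 share the butyl-linked oxadiazolone part and differ in the amine ring, so neither compares with compound 3 in one place alone.

Compound 4 `O=C1CCc2ccccc2N1CCCCN1CCN(c2ccc(F)cc2)CC1` is the next structure: 4-fluorophenyl in place of cyclohexyl on an amine nitrogen in a ring. For the measured compounds named here, no measured pair shows this exact change. Going by the values given here, compound 1, the only measured compound carrying the 4-fluorophenyl on that ring nitrogen, gives 383 nM, but its other half differs from compound 3, so no step can be read from it.

The expectation for compound 4 is a weaker number than compound 3, a step of a 3.8-fold higher number from compound 3 to compound 4 (0.58 log units; beyond the scatter) in this assay, beyond the scatter but moderate. The estimate for compound 4 is 80 nM, with a range from 25 nM to 300 nM.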

Compound 4, inhibition constant: 16 nM
For compound 4 the middle estimate is 5.0-fold (0.70 log units) above the measured one; measured number outside the range, below it.
By their numbers in this assay, from the lowest: compounds 4 and 3 (each within the scatter of the next); then compound 1; then compound 2.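

In this assay, 4-fluorophenyl in place of cyclohexyl on an amine nitrogen in a ring gives a 1.3-fold lower number from compound 3 to compound 4 (0.12 log units; within the scatter), so on this core the aromatic and the non-aromatic six-membered ring cannot be told apart. For the compounds shown here, this is the first step that isolates this position. The same 4-fluorophenyl stands in compound 1 at 383 nM and in compound 4 at 16 nM, so the number of compound 1 does not follow from this group alone.

From the compounds shown here alone, it remains open whether a plain phenyl or a benzyl on this nitrogen would read the same. Going by these compounds, it also remains open whether cyclohexyl on the butyl-linked oxadiazolone part would differ from the 4-fluorophenyl of compound 1.

No separate measurement bears on this result.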